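Ethylamino Replaces Dimethylamino on the Shared Core

A few compounds are considered here, and "the series" means these few. Any claim that something is new, unique, unknown or untested is made for them only; others in the source may bear on it.

Measured compounds:
compound 1 `OCCNc1[nH]ccc2ncnc1-2` gives < 5%
compound 2 `Nc1nccc2c1ncn2[C@H]1C[C@H](O)[C@@H](CO)O1` gives 89%
compound 3 `CN(C)c1[nH]ccc2ncnc1-2` gives 25%

In a functional assay on EL4 cells (Mus musculus) for inhibition, tested at 100 uM (on this read-out lower numbers stand for less inhibition and higher numbers for more inhibition at the one concentration tested (going by the name of the read-out)), compound 2 gives 89%. Compound 3 gives 25% in this assay, the lower of the two numbers, with compound 2 standing above it beyond the scatter. The value of compound 1 in this assay is a limit of the assay and not a number (the limit of < 5% in this assay, at which 1 of the 3 values shown sits). Within the data shown here, only one step joins two measured compounds here: a number at least 20 percentage points higher from compound 1 to compound 3 (beyond the scatter), a change on the shared core.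

The unmeasured compound 4 `CCNc1[nH]ccc2ncnc1-2` differs from compound 3 by ethylamino in place of dimethylamino on an aromatic carbon. This change runs the earlier step backward in part: a dimethylamino gives way to a group with one hydrogen-bond donor, as in compound 1, though without the hydroxyl of (2-hydroxyethyl)amino. Because a number at least 20 percentage points higher from compound 1 to compound 3 (beyond the scatter) was at least modest, the return is expected to cost, and the estimated step is a number 13 percentage points lower from compound 3 to compound 4 (beyond the scatter). Compound 4 is expected to give about 12% in this assay, within 0% to 30%.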

Compound 4, a percentage reported as inhibition, at one concentration (the size of the read-out at that concentration, not a potency): < 5%
Compound 4 was reported as a limit; the forecaster's own chance of this, stated with the estimate: 30%; middle value at least 7 percentage points away from the limit.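

In this assay, the exchange of dimethylamino for ethylamino on this aromatic carbon, with the heavy atom count unchanged, gives a number at least 20 percentage points lower from compound 3 to compound 4 (beyond the scatter). The reading of compound 4 is a limit of the assay, as is that of compound 1, so the step between these two cannot be read: the limit of < 5% in this assay, at which 2 of the 4 values shown sit. The earlier step left open whether the low reading of compound 1 went with its hydroxy group, but ethylamino has no hydroxy group, and on the shared core only dimethylamino, which lacks the hydrogen-bond donor of the other two groups, gives a reading that is not a limit. The compounds shown do not tell whether diethylamino, or a cyclic amine such as pyrrolidine or morpholine, would hold or raise the reading of compound 3. Going by these compounds, the effect of a plain amino group at this carbon also stays open.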